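Dropping the Chloro Group on the Aryl Ring

The compounds below may be only part of what the source reports. "The series", "measured", "known", "first", "only" and "open" are said of these compounds alone.

Measured so far:
compound 1, `Cc1cccc(N2CCn3c2n[nH]c(=O)c3=O)c1C`, 0%
compound 2, `N=c1c(=O)[nH]nc2n1CCN2c1cccc(Cl)c1`, 36%

Of the compounds shown here, two have been measured in a functional assay on A549 cells (Homo sapiens) for antiproliferative activity, with a stated time of 72 h, tested at 10 ug/mL; on this read-out lower numbers stand for a weaker effect and higher numbers for a stronger effect at the one concentration tested. Compound 1 gives 0% in this assay, while compound 2 gives 36%. Of the two numbers, compound 2 stands highest; its nearest neighbour is compound 1, whose number lies lower by a gap that is beyond the usual scatter. For the measured compounds named here, since the two compounds differ in more than one place, no single step connects them, and their values speak only for themselves.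

The next compound, compound 3, `N=c1c(=O)[nH]nc2n1CCN2c1ccccc1`, differs from compound 2 in one place: hydrogen in place of chloro on an aromatic carbon. The chloro that leaves sits on an aromatic carbon of a six-membered aromatic ring of carbon only, meta to a large group, and a hydrogen enters in its stead.

Going by the values given here, no measured step of this kind exists here, so the expectation rests on the single value of compound 2 alone. A modest downward step is expected, a number 14 percentage points lower from compound 2 to compound 3 (beyond the scatter), though one possibly within the scatter. Compound 3 is estimated to give 22% in this assay, with a likely range from 2% to 42%.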

Compound 3, a percentage reported as inhibition, at one concentration (the size of the read-out at that concentration, not a potency): 7%
Beside the measured number, compound 3's estimate is 15 percentage points above it; the range from low to high includes it.
By their numbers in this assay, from the lowest: compounds 1 and 3 (each within the scatter of the next); then compound 2.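

In this assay, for the compounds shown here, this is the first comparison that isolates a single change, since compound 1 and compound 2 differ in more than one place and could say nothing about any one group. Replacing the chloro on the six-membered aromatic ring, meta to a large group, with hydrogen gives a number 29 percentage points lower from compound 2 to compound 3 (beyond the scatter), so at this position the chloro accounts for a real part of the effect seen with compound 2, and the shared core with only hydrogen there, as in compound 3, gives just 7%. Nothing measured here bears on why the chloro makes this difference, so the step stands as an observation without an explanation.

What the compounds shown leave open is whether the effect depends on chloro itself or would also appear with another group at the same place, such as fluoro, bromo, methoxy or an amine. They also leave open whether a chloro elsewhere on the ring would give a number like that of compound 2, which at 36% remains a single reading at one concentration.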